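Swapping the Pyrazole for a Thiazole Ester

A few compounds are considered here, and "the series" means these few. Any claim that something is new, unique, unknown or untested is made for them only; others in the source may bear on it.

Compound 1 `CC1(C)CC(NC(=O)c2ccc(Nc3ncc([N+](=O)[O-])c(NC4CCCC4)n3)cc2)CC(C)(C)N1[O]`: 28700 nM
Compound 2 `Cc1cc(Nc2nc(Nc3ccc(C(=O)NC4CC(C)(C)N([O])C(C)(C)C4)cc3)ncc2[N+](=O)[O-])no1`: 7360 nM
Compound 3 `Cc1cc(Nc2nc(Nc3ccc(C(=O)NC4CC(C)(C)N([O])C(C)(C)C4)cc3)ncc2[N+](=O)[O-])n[nH]1`: 37500 nM

All three share one core and differ only in the group on a nitrogen on an aromatic ring. In a functional assay on HepG2 cells (Homo sapiens) for antiproliferative activity, read by MTT assay, with a stated time of 48 h (on this read-out lower numbers stand for stronger inhibition and higher numbers for weaker inhibition), compound 3 gives 37500 nM, the highest of the three numbers. Against compound 1 the step is a 1.3-fold higher number from compound 1 to compound 3 (0.12 log units; within the scatter); against compound 2 it is a 5.1-fold higher number from compound 2 to compound 3 (0.71 log units; beyond the scatter). Compound 4 `CCOC(=O)Cc1csc(Nc2nc(Nc3ccc(C(=O)NC4CC(C)(C)N([O])C(C)(C)C4)cc3)ncc2[N+](=O)[O-])n1` carries 4-((ethoxycarbonyl)methyl)-1,3-thiazol-2-yl in place of 5-methyl-1H-pyrazol-3-yl on a nitrogen on an aromatic ring. Among the measured compounds shown here, no measured step covers a thiazole, so the guide is the pair of ring swaps already seen: a 3.9-fold lower number from compound 1 to compound 2 (0.59 log units; beyond the scatter) and a 5.1-fold higher number from compound 2 to compound 3 (0.71 log units; beyond the scatter), both modest. Compound 4, like compound 2, has no donor on the ring, and a modest fall is therefore expected here because compound 2 gave 7360 nM. Compound 4 is expected to give 12000 nM (range 3500 nM to 40000 nM), meaning a step of a 3.1-fold lower number from compound 3 to compound 4 (0.49 log units; beyond the scatter).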

Compound 4, half-maximal inhibitory concentration: 26400 nM
The estimate for compound 4 lay 2.2-fold (0.34 log units) below the measured number; the measured number falls inside the stated range.
By their numbers in this assay, from the lowest: compound 2; then compounds 4, 1 and 3 (each within the scatter of the next).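

In this assay, the 4-((ethoxycarbonyl)methyl)-1,3-thiazol-2-yl group cannot be told apart from the pyrazole (a 1.4-fold lower number from compound 3 to compound 4 (0.15 log units; within the scatter)) or from cyclopentyl (a 1.1-fold lower number from compound 1 to compound 4 (0.04 log units; within the scatter)). Having no hydrogen-bond donor on this ring therefore does not by itself match the oxazole of compound 2 (a 3.6-fold higher number from compound 2 to compound 4 (0.55 log units; beyond the scatter)). Nothing measured here explains why the oxazole stands apart.

Going by these compounds, it remains open whether the thiazole ring or its ester side chain sets this number. A plain methyl on the thiazole, or a carboxylic acid in place of the ethyl ester, would separate the two.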